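The source may hold more compounds than are shown below. What is called first, only, known or untested is meant among the compounds shown, and "the series" means these compounds.

Three compounds have been measured in a functional assay on the whole organism (Tail, strain ICR) with Mus musculus as the target, in the tail flick test, with a stated time of 60 min, at a dose of 25 umol/kg by the oral route; a higher number here means a stronger effect of the compound at the dose given, a lower number a weaker effect:

Compound 1 `O=C(CN(c1ncnc2c1ncn2C1CCCCO1)C1CC1)NCC(=O)OCc1ccccc1` gives 40.4%
Compound 2 `CC[C@H](C)[C@H](NC(=O)CN(c1ncnc2c1ncn2C1CCCCO1)C1CC1)C(=O)OCc1ccccc1` gives 27.4%
Compound 3 `C[C@@H](O)[C@H](NC(=O)CN(c1ncnc2c1ncn2C1CCCCO1)C1CC1)C(=O)OCc1ccccc1` gives 28.4%

Compound 3 stands second highest of these three numbers. Its nearest neighbour is compound 2, within the scatter; its furthest is compound 1, whose number is higher by a step beyond the scatter. Compound 4 `NC(=O)C[C@H](NC(=O)CN(c1ncnc2c1ncn2C1CCCCO1)C1CC1)C(=O)OCc1ccccc1` has not yet been measured. Compared with compound 3 it carries carbamoylmethyl in place of 1-hydroxyethyl on a saturated chain carbon bound to an amide-type nitrogen and a carbonyl carbon.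

Two kinds of measured step bear on this change. The steps of a number 13 percentage points lower from compound 1 to compound 2 (beyond the scatter) and a number 12 percentage points lower from compound 1 to compound 3 (beyond the scatter) show that a side chain, whether sec-butyl or 1-hydroxyethyl, in place of hydrogen at this carbon lowered the read-out modestly. The step of a number 1 percentage points higher from compound 2 to compound 3 (within the scatter) shows that hydroxy in place of ethyl within such a side chain left the number within the scatter. Compound 4 also keeps a side chain at that place, only a different one, so the step of a number 0.4 percentage points lower from compound 3 to compound 4 (within the scatter) is expected to stay within the scatter, with no clear direction. Compound 4 is therefore expected to give 28% in this assay, most likely between 17% and 40%.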

Compound 4, a percentage reported as activity, at one dose (the size of the read-out at that dose, not a potency): 30.5%
The estimate for compound 4 lay 2.5 percentage points below the measured number; the range from low to high includes it.
By their numbers in this assay, from the lowest: compounds 2, 3, 4 and 1 (each within the scatter of the next, the first and the last beyond it).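

In this assay, carbamoylmethyl at this carbon cannot be told apart from the two other side chains, with a step to 1-hydroxyethyl (a number 2.1 percentage points higher from compound 3 to compound 4 (within the scatter)) and one to sec-butyl (a number 3.1 percentage points higher from compound 2 to compound 4 (within the scatter)), so three different side chains now read alike here. The new point is the comparison with hydrogen at the same carbon: this step (a number 9.9 percentage points lower from compound 1 to compound 4 (within the scatter)) stays within the scatter, whereas the steps to sec-butyl and 1-hydroxyethyl went beyond it, so the drop seen with those two side chains is not clearly repeated with carbamoylmethyl. No measurement here offers an explanation for these numbers.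

As far as these compounds go, whether an amine or a carboxylic acid in this side chain, or a longer chain ending in the same carbamoyl group, would separate from these compounds remains open. A read-out at one dose also leaves open how the compounds would compare at other doses.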